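The compounds below may be only part of what the source reports. "The series", "measured", "known", "first", "only" and "open" are said of these compounds alone.

- Compound 1 `Cc1oc2c([C@H]3CCN(C)C[C@H]3O)c(O)cc(O)c2c(=O)c1C(O)c1ccc(F)c(Br)c1`: 14%
- Compound 2 `Cc1oc2c([C@H]3CCN(C)C[C@H]3O)c(O)cc(O)c2c(=O)c1C(O)c1c(F)cccc1Cl`: 41%

Of the two compounds measured in a functional assay on MCF7 cells (Homo sapiens) for inhibition, read by MTT assay, with a stated time of 48 h, tested at 10 uM (on this read-out higher numbers stand for more inhibition of growth at the one concentration tested and lower numbers for less inhibition of growth), compound 2 stands higher, at 41%. Compound 3 `Cc1oc2c([C@H]3CCN(C)C[C@H]3O)c(O)cc(O)c2c(=O)c1C(O)c1csc([N+](=O)[O-])c1` carries 5-nitrothiophen-3-yl in place of 2-chloro-6-fluorophenyl on a saturated chain carbon bound to an aromatic carbon and an oxygen on a saturated carbon. Going by the values given here, the one measured step at this place is a number 27 percentage points higher from compound 1 to compound 2 (beyond the scatter), which shows that exchanging this group can move the number. Neither measured compound has a thiophene ring, so direction is uncertain, and a modest fall towards compound 1 at 14% seems likeliest. The expected change is a number 13 percentage points lower from compound 2 to compound 3 (beyond the scatter). Compound 3 is estimated at 28%, with an expected range from 8% to 50%.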

Compound 3, percent growth inhibition at one concentration: 20%
For compound 3 the middle estimate is 8 percentage points above the measured one; the measured number falls inside the stated range.
By their numbers in this assay, from the lowest: compounds 1 and 3 (each within the scatter of the next); then compound 2.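

In this assay, 5-nitrothiophen-3-yl in place of 2-chloro-6-fluorophenyl gives a number 21 percentage points lower from compound 2 to compound 3 (beyond the scatter) while the same group in place of 3-bromo-4-fluorophenyl gives a number 6 percentage points higher from compound 1 to compound 3 (within the scatter) at this same place. So a five-membered ring carrying a nitro group and the 3-bromo-4-fluorophenyl ring cannot be told apart here, and among these three compounds only compound 2 stands apart. No measurement here explains why. Still open, as far as these compounds go, is whether the chlorine or the fluorine of compound 2 matters more. Also open, from the compounds shown here alone, is what a plain phenyl, a pyridine ring or an amine-bearing chain would give on this carbon.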